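Acetoxy ester of the hydroxyethyl side chain: cytotoxicity outlook

A few compounds are considered here, and "the series" means these few. Any claim that something is new, unique, unknown or untested is made for them only; others in the source may bear on it.

Going by the values given here, the three measured members share one core. Compound 1 `O=C1c2ccccc2NS(=O)(=O)N1COCCO` in a functional assay on HEL cells (Homo sapiens) for cytotoxicity (on this read-out lower numbers stand for higher toxicity in this test and higher numbers for lower toxicity in this test), gives only an assay limit, > 50 ug/mL. For compound 2 `O=C1NS(=O)(=O)N(COCCO)c2ccccc21` the read-out in this assay is likewise a limit, > 50 ug/mL. Compound 3 `O=C1c2ccccc2N(COCCO)S(=O)(=O)N1Cc1ccccc1` also returns a limit in this assay, > 50 ug/mL. Among the compounds with values here, the single one-point step, a step that the two limits leave unreadable from compound 2 to compound 3, is therefore unreadable, since every value sits at the limit of > 50 ug/mL in this assay, at which 3 of the 3 values shown sit.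

Compound 4 `CC(=O)OCCOCN1c2ccccc2C(=O)NS1(=O)=O` differs from compound 2 by acetyl in place of hydrogen on an oxygen on a saturated carbon. Within the data shown here, no measured step bears on an ester in place of the free hydroxy, and the step between compound 2 and compound 3 offers no size to borrow. In this assay compound 4 is expected to stay at the limit, an estimate of 100 ug/mL (range 50 ug/mL to 200 ug/mL). The expected step that the limit leaves unreadable from compound 2 to compound 4 is thus none beyond the scatter.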

Compound 4, minimum cytotoxic concentration: > 50 ug/mL
Compound 4: a limit, no number; the forecaster's own chance of this, stated with the estimate: 85%; the middle value lies beyond the limit too.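

Compound 2 and compound 4 both give only limits in this assay, so no step between them can be read: the limit of > 50 ug/mL in this assay, at which 4 of the 4 values shown sit.

The compounds shown leave open whether any change to the shared core gives a numerical minimum cytotoxic concentration in this assay.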